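Compound 3 to compound 4: a naphthalen-1-yl swap

A few compounds are considered here, and "the series" means these few. Any claim that something is new, unique, unknown or untested is made for them only; others in the source may bear on it.

Values measured so far in an ADME assay on MT4 cells (Homo sapiens) for cytotoxicity, read by MTT assay (on this read-out lower numbers stand for higher toxicity in this test and higher numbers for lower toxicity in this test), are these:
Compound 1 (`Cc1ccc(C(=O)N(C(=S)OCCN2C(=O)c3ccccc3C2=O)c2ccc(Cl)cc2)cc1`) gives > 100000 nM (a limit of the assay, not a number)
Compound 2 (`O=C1c2ccccc2C(=O)N1CCOC(=S)N(C(=O)c1ccc(F)c(F)c1)c1ccc(Cl)cc1`) gives 52000 nM (a number)
Compound 3 (`O=C1c2ccccc2C(=O)N1CCOC(=S)N(C(=O)c1ccc(Cl)c([N+](=O)[O-])c1)c1ccc(Cl)cc1`) gives 48000 nM (a number)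

Compound 3, at 48000 nM in this assay, stands level with compound 2, at 52000 nM on the same read-out, the two lying within the scatter of each other. The next compound to be tested is compound 4 (`O=C1c2ccccc2C(=O)N1CCOC(=S)N(C(=O)c1cccc2ccccc12)c1ccc(Cl)cc1`), which carries naphthalen-1-yl in place of 4-chloro-3-nitrophenyl on a carbonyl carbon.

All three measured steps change this same place. The closest guide is a 1.1-fold lower number from compound 2 to compound 3 (0.03 log units; within the scatter), a swap of one substituted phenyl group for another that left the number where it was. The other two start from a limit, so they give only floors: an at least 1.9-fold lower number from compound 1 to compound 2 (0.28 log units; that floor lies within the scatter) and an at least 2.0-fold lower number from compound 1 to compound 3 (0.31 log units; beyond the scatter). None of them involves naphthalen-1-yl, and its effect remains unmeasured. No step beyond the scatter is therefore expected in this assay in either direction, though compound 4 could also reach the limit of the assay. Going by the values given here, the expected change, resting on a 1.1-fold lower number from compound 2 to compound 3 (0.03 log units; within the scatter) as the only step with two real numbers, is a 1.0-fold higher number from compound 3 to compound 4 (0.02 log units; within the scatter) for now. For compound 4 the estimated value is 50000 nM (expected range from 20000 nM to 100000 nM).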

Compound 4, half-maximal cytotoxic concentration: 6000 nM
Compound 4: the middle estimate sits 8.3-fold (0.92 log units) above what was measured; measured number below the stated range.
By their numbers in this assay, from the lowest: compound 4; then compounds 3 and 2 (each within the scatter of the next). At a limit, above all of these: compound 1.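

In this assay, this place on the carbonyl carbon can move the number beyond the scatter between measured values: the result is an 8.0-fold lower number from compound 3 to compound 4 (0.90 log units; beyond the scatter) and an 8.7-fold lower number from compound 2 to compound 4 (0.94 log units; beyond the scatter), whereas the exchange of one substituted phenyl group for another gave a 1.1-fold lower number from compound 2 to compound 3 (0.03 log units; within the scatter). Compound 4 holds the lowest number shown, with its steps to all the other compounds beyond the scatter, and its naphthalen-1-yl group is the only one here with 2 six-membered aromatic rings of carbon only, although it has the same 10 heavy atoms as the 4-chloro-3-nitrophenyl group it replaces. The remaining result, an at least 16-fold lower number from compound 1 to compound 4 (1.22 log units; beyond the scatter), is only a floor, because compound 1 rests on a limit and not on a number: the limit of > 100000 nM in this assay, at which 1 of the 4 values shown sits.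

The compounds shown leave open whether a benzyl group, or a naphthalen-1-yl group carrying an amine, on this carbonyl carbon would give a number like that of compound 4. Nor do they tell whether the step would hold with another group elsewhere on the shared core.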